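Shifting one methyl group on the dimethylphenyl ring

The compounds below may be only part of what the source reports. "The series", "measured", "known", "first", "only" and "open" are said of these compounds alone.

Compound 1 `CCc1ccccc1-c1nc(CN2CCC(C(=O)NCCCN3C[C@H](C)C[C@H](C)C3)CC2)c(C)o1` gives 55.9 ug/mL
Compound 2 `Cc1ccc(-c2nc(CN3CCC(C(=O)NCCCN4C[C@H](C)C[C@H](C)C4)CC3)c(C)o2)cc1C` gives > 71 ug/mL (a limit of the assay, not a number)

Both results come from a physicochemical assay for solubility, in phosphate buffer, measured as kinetic solubility, at pH 7.4 (on this read-out higher numbers stand for higher solubility and lower numbers for lower solubility), and belong to compounds with the same core. Compound 2 has no exact number here, only a limit (> 71 ug/mL).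

Compound 3 `Cc1ccc(-c2nc(CN3CCC(C(=O)NCCCN4C[C@H](C)C[C@H](C)C4)CC3)c(C)o2)c(C)c1` has the same atoms as compound 2, joined differently. On an aromatic carbon of the five-membered aromatic ring, 2,4-dimethylphenyl stands in place of 3,4-dimethylphenyl (2,4-dimethylphenyl in place of 3,4-dimethylphenyl on an aromatic carbon).

For the measured compounds named here, one measured step bears on this, a change of group at that same carbon (an at least 1.2-fold higher number from compound 1 to compound 2 (0.10 log units; that floor lies within the scatter)), and its floor lies within the scatter. Compound 1, which carries 2-ethylphenyl, gives a measured number (55.9 ug/mL). With so little to go on, no step beyond the scatter is expected in this assay, in either direction. A limit is possible again for compound 3, given how the values sit (the limit of > 71 ug/mL in this assay, at which 1 of the 2 values shown sits).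

The expected step is small (an at least 1.1-fold lower number from compound 2 to compound 3 (0.05 log units; that floor lies within the scatter)). For compound 3 the estimated value is 62 ug/mL (expected range 35 ug/mL to 80 ug/mL)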

Compound 3, solubility: > 71 ug/mL
Compound 3 was reported as a limit (the forecaster's own chance of this, stated with the estimate: 45%); middle value at least 1.1-fold (0.05 log units) away from the limit.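

In this assay compound 3 gives > 71 ug/mL as a limit of the assay, not a number. Set against the 2-ethylphenyl group, 2,4-dimethylphenyl gives an at least 1.2-fold higher number from compound 1 to compound 3 (0.10 log units; that floor lies within the scatter) and so, like 3,4-dimethylphenyl before it, shows no step that can be told from the scatter. What is new is that moving one methyl group around the phenyl ring leaves the result at the same limit, so the step between compound 2 and compound 3 cannot be read: the limit of > 71 ug/mL in this assay, at which 2 of the 3 values shown sit.

From the compounds shown here alone, whether compound 2 and compound 3 truly differ, and by how much, stays open, as does how far either one lies past the limit. Also open is how this assay would respond if this phenyl ring carried an amine or a carboxylic acid instead of its methyl groups, since every group shown at this carbon is a phenyl ring bearing only small carbon chains.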